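The compounds below may be only part of what the source reports. "The series", "measured", "known", "first", "only" and "open" are said of these compounds alone.

Measured so far in an ADME assay on the whole organism for pharmacokinetics, with Rattus norvegicus as the target, with a stated time of 6 h, at a dose of 10 mg/kg by the oral route; a higher number here means more compound in the circulation at the dose given, a lower number less compound in the circulation:

Compound 1, `Cc1cn2c(-c3cn[nH]c3)cnc2c(Nc2cc(Cc3nccs3)ns2)n1`: 1540 ng.h/mL
Compound 2, `Cc1cn2c(-c3cn[nH]c3)cnc2c(Nc2cc(Cc3ncccc3C)ns2)n1`: 644 ng.h/mL

Compound 2 stands at the lower of the two numbers. Within the data shown here, the one measured step that connects them is a 2.4-fold lower number from compound 1 to compound 2 (0.38 log units; beyond the scatter); that exchange replaced a five-membered ring bearing two hetero atoms with a six-membered methylpyridine ring, and the exposure in the circulation fell by a modest but real amount.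

Compound 3, `Cc1cccc(Cc2cc(Nc3nc(C)cn4c(-c5cn[nH]c5)cnc34)sn2)n1`, has not yet been measured in this assay. It differs from compound 2 as follows: 6-methylpyridin-2-yl in place of 3-methylpyridin-2-yl on a saturated chain carbon bound to an aromatic carbon. Both compounds contain the same atoms, joined differently, so the methyl group simply sits at another place on the pyridine ring.

Among the measured compounds shown here, the only measured step, from a thiazole to a methylpyridine, does not move a methyl group around a ring, so it offers little guidance for this change. Without a measured precedent, the expectation is a step of no more than the usual scatter, in no clear direction. Compound 3 is therefore estimated to give 650 ng.h/mL, in a range from 300 ng.h/mL to 1400 ng.h/mL. That estimate corresponds to an expected step of a 1.0-fold higher number from compound 2 to compound 3 (0.00 log units; within the scatter).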

Compound 3, area under the concentration-time curve: 3100 ng.h/mL
Compound 3: middle estimate off by 4.8-fold (0.68 log units), on the low side; measured number outside the range, above it.
By their numbers in this assay, from the lowest: compound 2; then compounds 1 and 3 (each within the scatter of the next).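

In this assay, the position on the saturated chain carbon bound to an aromatic carbon proves sensitive to where a single methyl group sits on the pyridine: 6-methylpyridin-2-yl in place of 3-methylpyridin-2-yl keeps the same atoms, yet the result is large (a 4.8-fold higher number from compound 2 to compound 3 (0.68 log units; beyond the scatter)). The earlier fall seen with 3-methylpyridin-2-yl therefore cannot be read as a verdict on methylpyridines in general at this position, and 6-methylpyridin-2-yl in place of 1,3-thiazol-2-yl shows no real change (a 2.0-fold higher number from compound 1 to compound 3 (0.30 log units; within the scatter)). Nothing shown here explains why moving the methyl group alters the amount of compound in the circulation so strongly.

The compounds shown leave open what a plain pyridin-2-yl, carrying no methyl group at all, would give, and so whether the 3-methyl group lowers the number, the 6-methyl group raises it, or both. They also leave open whether a methoxy group, an amine or a longer chain such as ethyl, in place of the methyl group of 6-methylpyridin-2-yl, would keep the higher number.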